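A few compounds are considered here, and "the series" means these few. Any claim that something is new, unique, unknown or untested is made for them only; others in the source may bear on it.

Measured compounds:
- Compound 1 `COc1ccc(/C=C/C(=O)c2cc(-c3ccc(OC)c(OC)c3)n3nc(-c4ccccc4)cc3n2)cc1` gives, in a functional assay on DU-145 cells (Homo sapiens) for antiproliferative activity, read by MTT assay, with a stated time of 24 h (on this read-out higher numbers stand for weaker inhibition and lower numbers for stronger inhibition), 14900 nM.
- Compound 2 `COc1ccc(-c2cc(C(=O)/C=C/c3ccc(Cl)cc3)nc3cc(-c4ccccc4)nn23)cc1OC` gives in this assay 22400 nM.
- Compound 3 `COc1ccc(-c2cc(C(=O)/C=C/c3ccc(C)cc3)nc3cc(-c4ccccc4)nn23)cc1OC` gives in this assay 19500 nM.

Among these three numbers compound 3 stands second highest, with compound 2 nearest and compound 1 furthest, and every gap between them lies within the scatter of this kind of measurement. Among the measured compounds shown here, the three compounds share one core and differ only in the single group on the aromatic ring at the far end of the double-bonded chain. The steps of a 1.5-fold higher number from compound 1 to compound 2 (0.18 log units; within the scatter), a 1.3-fold higher number from compound 1 to compound 3 (0.12 log units; within the scatter) and a 1.1-fold lower number from compound 2 to compound 3 (0.06 log units; within the scatter) were all too small to count as real changes.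

Compound 4 `COc1ccc(-c2cc(C(=O)/C=C/c3cc(OC)c(OC)c(OC)c3)nc3cc(-c4ccccc4)nn23)cc1OC` takes that change further: 3,4,5-trimethoxyphenyl in place of 4-methylphenyl on a double-bonded chain carbon bound to a double-bonded chain carbon. For the measured compounds named here, none of the measured steps covers the entry of three methoxy groups at once, so they bear on it only loosely, by showing that swapping one small group for another on this ring left this assay unchanged. On that basis no step beyond the scatter is expected, with wide uncertainty because the change is larger than any measured one. The expected step is a 1.5-fold lower number from compound 3 to compound 4 (0.18 log units; within the scatter). Compound 4 is therefore estimated at 13000 nM, within a range from 4000 nM to 40000 nM.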

Compound 4, half-maximal inhibitory concentration: 14700 nM
The estimate for compound 4 lay 1.1-fold (0.05 log units) below the measured number; the range from low to high includes it.
By their numbers in this assay, from the lowest: compounds 4, 1, 3 and 2 (each within the scatter of the next).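

Adding three methoxy groups at once is a larger change than any single swap among the earlier compounds, yet in this assay it still gives no step beyond the scatter: 3,4,5-trimethoxyphenyl gives a 1.3-fold lower number from compound 3 to compound 4 (0.12 log units; within the scatter) against 4-methylphenyl, a 1.5-fold lower number from compound 2 to compound 4 (0.18 log units; within the scatter) against 4-chlorophenyl and a 1.0-fold lower number from compound 1 to compound 4 (0.01 log units; within the scatter) against 4-methoxyphenyl. This place on the double-bonded chain therefore holds a group of 12 heavy atoms as well as one of 7, with the number staying level across all four compounds. Nothing measured here explains why the number stays level.

Every compound shown carries a six-membered aromatic ring at this place, so what an open-chain amine or a carboxylic acid would do there remains open. The rest of the molecule is identical throughout, which leaves open whether changes elsewhere would shift the number beyond the scatter.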